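Swapping the primary amide of compound 3 for a sulfone-bearing ring

The source may report more compounds than this note shows. Statements on the series, on what has been measured and on what is new or still open speak of the compounds shown alone.

Measured compounds in a physicochemical assay for lipophilicity; on this read-out higher numbers stand for higher lipophilicity and lower numbers for lower lipophilicity:
compound 1 `CC[C@H](C)[C@H](NC(=O)[C@H](CC(=O)O)NC(=O)CCCOc1ccc(C(=N)N)cc1)C(=O)O`: 1.47
compound 2 `Cc1ccc(OCCNC(=O)C(CC(=O)O)NC(=O)CCCOc2ccc(C(=N)N)cc2)cc1C`: 1.43
compound 3 `CC(C)[C@H](NC(=O)[C@H](CC(=O)O)NC(=O)CCCOc1ccc(C(=N)N)cc1)C(N)=O`: 0.891

Compound 3 stands lowest of the three in this assay; compound 2 is nearest, and compound 1 furthest, both beyond the scatter. Going by the values given here, the one step measured so far, a number 0.58 log units lower from compound 1 to compound 3 (beyond the scatter), changes two things at once and does not touch the carbonyl carbon where compound 4 `CC(C)[C@H](NC(=O)[C@H](CC(=O)O)NC(=O)CCCOc1ccc(C(=N)N)cc1)C(=O)N1CCS(=O)(=O)CC1` differs from compound 3. That difference is 1,1-dioxothiomorpholin-4-yl in place of amino on a carbonyl carbon. Among the compounds with values here, no measured step bears directly on it, so the expectation rests on the general character of the exchange: a hydrogen-bond donor leaves, a six-membered ring with a sulfone enters. These are expected to roughly offset, so the step of a number 0.11 log units higher from compound 3 to compound 4 (within the scatter) is estimated to lie within the scatter. For compound 4 in this assay a value of 1 is expected, with a likely range from 0.5 to 1.5.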

Compound 4, partition coefficient: 0.804
Estimate against measurement, compound 4: 0.20 log units above, and the stated range covers the measured number.
By their numbers in this assay, from the lowest: compounds 4 and 3 (each within the scatter of the next); then compounds 2 and 1 (each within the scatter of the next).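

In this assay, putting 1,1-dioxothiomorpholin-4-yl in place of amino on a carbonyl carbon gives a number 0.09 log units lower from compound 3 to compound 4 (within the scatter), so this read-out does not separate the two compounds. The step from compound 1 to compound 3 changed two things at once, whereas this one is confined to the carbonyl carbon and shows that a much larger ring-bearing group, with no hydrogen-bond donor and with hydrogen-bond acceptors, can stand there without a change beyond the scatter. Nothing available explains why the number holds across this exchange.

The compounds shown leave open whether a morpholin-4-yl or piperidin-1-yl ring on the same carbonyl carbon would also stay within the scatter of compound 3. They also leave open how a dimethylamino group would read there.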